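A few compounds are considered here, and "the series" means these few. Any claim that something is new, unique, unknown or untested is made for them only; others in the source may bear on it.

Compound 2, with structure `O=C(Nc1ccc(C(F)(F)F)cc1)c1ccc(OC(F)(F)F)cc1`, gives 220 nM in a functional assay on HEK293 cells for antagonist activity at transient receptor potential cation channel subfamily V member 1 (Homo sapiens), read by calcium flux; a higher number here means a weaker inhibitor, a lower number a stronger inhibitor. Going by the values given here, that is the higher of the two numbers so far: compound 1, `CC(C)(C)c1ccc(NC(=O)c2ccc(OC(F)(F)F)cc2)cc1`, gives 120 nM, and the step of a 1.8-fold higher number from compound 1 to compound 2 (0.26 log units; within the scatter). Compound 3, `O=C(Nc1ccc(C2CCCCC2)cc1)c1ccc(OC(F)(F)F)cc1`, differs from compound 2 by cyclohexyl in place of trifluoromethyl on an aromatic carbon. Among the compounds with values here, the only measured step touching this position is that one from compound 1 to compound 2, and it stayed within the scatter, so for compound 3 a step of a 1.6-fold lower number from compound 2 to compound 3 (0.20 log units; within the scatter) is expected, nothing beyond the scatter. The estimate for compound 3 is 140 nM, between 50 nM and 400 nM.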

Compound 3, half-maximal inhibitory concentration: > 10000 nM
Compound 3 ended at the assay's limit; the forecaster's own chance of this, stated with the estimate: 5%; middle value at least 71-fold (1.85 log units) from the limit.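

Compound 3 sits at a limit of the assay, not at a number: the limit of > 10000 nM in this assay, at which 1 of the 3 values shown sits.

The position is therefore not indifferent to the group it carries: cyclohexyl in place of trifluoromethyl gives an at least 45-fold higher number from compound 2 to compound 3 (1.65 log units; beyond the scatter), and cyclohexyl in place of tert-butyl gives an at least 83-fold higher number from compound 1 to compound 3 (1.92 log units; beyond the scatter). The earlier exchange of tert-butyl for trifluoromethyl, a 1.8-fold higher number from compound 1 to compound 2 (0.26 log units; within the scatter), gave no sign of such a drop.

The compounds shown cannot tell whether the ring of cyclohexyl or its carbon count is what matters. From the compounds shown here alone, whether a cyclopropyl, a longer chain or an amine at this place keeps the inhibition also stays open.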